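From a ring amine to a carbonyl-bearing group

A few compounds are considered here, and "the series" means these few. Any claim that something is new, unique, unknown or untested is made for them only; others in the source may bear on it.

Of the compounds shown here, two have been measured in an assay on isolated protein for activation of cGMP-dependent protein kinase 1 (Homo sapiens), read by ADP-Glo, with stated times of 30 min and 2 h, in the presence of a further agent that is not named here; on this read-out higher numbers stand for an effect only at larger amounts of compound and lower numbers for an effect already at smaller amounts. Compound 1, `COc1cccc([C@@H](CO)O[C@H]2CCCN(Cc3ccc(C(=O)O)cc3C)[C@H]2c2ccccc2)c1`, gives 81000 nM. Compound 2, `Cc1cc(C(=O)O)ccc1C(C)N1CCC[C@H](O[C@H](CO)c2cc(Cl)cc(Cl)c2)[C@@H]1c1ccccc1`, gives 18000 nM, the lower of the two numbers; the gap between compound 2 and compound 1 is larger than the usual scatter of repeated measurements, so compound 2 is the more active of the pair. Going by the values given here, no comparison between measured compounds that differ in only one place exists in this set.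

Compound 3, `Cc1cc(C(=O)O)ccc1C(=O)N1CCC[C@H](O[C@H](CO)c2cc(Cl)cc(Cl)c2)[C@@H]1c1ccccc1`, is still to be measured. It differs from compound 2 in one place: a group of 12 heavy atoms (9 carbon, 3 oxygen; one six-membered aromatic ring of carbon only) in place of a group of 12 heavy atoms (10 carbon, 2 oxygen; one six-membered aromatic ring of carbon only), on an amine nitrogen in a ring. The ring nitrogen keeps its place on the shared core, and only the group hanging from it is exchanged.

Nothing measured here shows how such an exchange moves the read-out, so its direction is open. The step that this estimate means, a 1.7-fold higher number from compound 2 to compound 3 (0.22 log units; within the scatter), is expected to be modest, within or only a little beyond the scatter. Compound 3 is therefore estimated at 30000 nM, with a range from 8000 nM to 120000 nM.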

Compound 3, half-maximal effective concentration: > 200000 nM
Compound 3: a limit, no number; the forecaster's own chance of this, stated with the estimate: 20%; at least 6.6-fold (0.82 log units) between middle value and limit.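

Compound 3 gives no number in this assay, only a limit of the assay: the limit of > 200000 nM in this assay, at which 1 of the 3 values shown sits.

Going by these compounds alone, the exchange on the amine nitrogen in a ring still gives an at least 11-fold higher number from compound 2 to compound 3 (1.04 log units; beyond the scatter), and this is the first comparison here in which the compounds differ in only one place, so it shows that the read-out responds to what sits on this nitrogen. Both groups hold 12 heavy atoms and one six-membered aromatic ring of carbon only, yet the group that enters, with 2 double bonds outside aromatic rings and 2 hydrogen-bond acceptors in place of 1 and 1, gives a step beyond the usual scatter, so a group of the same size does not ensure a similar result at this position.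

This single step cannot say which feature of the exchange matters, as the group that enters differs from the group that leaves in more than one respect. How a sulfonyl group in place of the carbonyl, or a longer chain carrying the same aromatic ring, would behave on this nitrogen remains open in the compounds shown.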